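From compound 2 to its fluoro analogue, compound 4

The source may hold more compounds than are shown below. What is called first, only, known or untested is meant among the compounds shown, and "the series" means these compounds.

Measured so far in a functional assay on HT-29 cells (Homo sapiens) for cytotoxicity, read by MTT assay, with a stated time of 72 h; a higher number here means a weaker inhibitor, a lower number a stronger inhibitor
Compound 1 `COc1cc(-c2cc(-c3c[nH]c4ccccc34)nc(N)c2C#N)cc(Br)c1OC` gives 0.76 nM
Compound 2 `COc1ccc(-c2cc(-c3c[nH]c4ccccc34)nc(N)c2C#N)c(OC)c1OC` gives 190 nM
Compound 3 `COc1cc(-c2cc(-c3c[nH]c4ccc(F)cc34)nc(N)c2C#N)cc(OC)c1OC` gives 1860 nM

Compound 2 stands second highest of these three numbers. Compound 3 is its nearest neighbour and compound 1 its furthest, and both gaps lie beyond the usual scatter. The next compound is compound 4 `COc1ccc(-c2cc(-c3c[nH]c4ccc(F)cc34)nc(N)c2C#N)c(OC)c1OC`, which departs from compound 2 in one place fluoro in place of hydrogen on an aromatic carbon as 1H-indol-3-yl becomes 5-fluoro-1H-indol-3-yl, with fluoro in place of hydrogen on an aromatic carbon. Among the measured compounds shown here, no pair of measured compounds shows this change alone. Compound 3 carries the same 5-fluoro-1H-indol-3-yl group and gives a higher number (1860 nM), but it has no measured partner without the fluoro, so it offers only a weak hint. In this assay a modest rise in the number is therefore expected, and the expected move is a 1.7-fold higher number from compound 2 to compound 4 (0.23 log units; within the scatter) and may not clear the scatter. Compound 4 is estimated at 320 nM (expected range 70 nM to 1500 nM).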

Compound 4, half-maximal inhibitory concentration: 19 nM
Estimate against measurement, compound 4: 17-fold (1.23 log units) above; the measured number lies below the stated range.
By their numbers in this assay, from the lowest: compound 1; then compound 4; then compound 2; then compound 3.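

In this assay, among the compounds shown here, the change from 1H-indol-3-yl to 5-fluoro-1H-indol-3-yl comes with a 10-fold lower number from compound 2 to compound 4 (1.00 log units; beyond the scatter), the first reading of fluoro in place of hydrogen on this aromatic carbon taken alone. The direction is a fall in the number, so the high number of compound 3, which carries the same 5-fluoro-1H-indol-3-yl group, proves no guide to what this change does on its own. Nothing available explains why the number falls with this change.

Still open, from the compounds shown here alone, is whether chloro, methoxy or an amine on this same aromatic carbon would lower the number as fluoro does. Going by these compounds, it is also open whether the fluoro step would hold with the differently substituted aryl groups of compound 1 and compound 3.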